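This account rests on a few compounds, and the source may have more. Where it says the series, first, only, none or still open, it means among the compounds named here.

Compound 3 `COc1cc2ncnc(Nc3ccc(F)c(Cl)c3)c2cc1NC(=O)N/N=C/c1ccc(C#N)cc1` is the weakest-looking entry of the three measured compounds in a functional assay on HepG2 cells (Homo sapiens) for cytotoxicity, read by MTT assay, with a stated time of 72 h (a higher number here means a weaker inhibitor, a lower number a stronger inhibitor), where compound 3 gives 34100 nM. Its nearest neighbour is compound 1 `N#Cc1ccc(/C=N/NC(=O)Nc2cc3c(Nc4ccc(F)c(Cl)c4)ncnc3cc2O[C@H]2CCOC2)cc1`, which in this assay gives 26400 nM; the two differ only in a 1.3-fold higher number from compound 1 to compound 3 (0.11 log units; within the scatter). Far below both is compound 2 `O=C(N/N=C/c1ccc(O)c(Br)c1)Nc1cc2c(Nc3ccc(F)c(Cl)c3)ncnc2cc1O[C@H]1CCOC1`, which gives 660 nM.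

Compound 4 `CCN(CC)c1ccc(/C=N/NC(=O)Nc2cc3c(Nc4ccc(F)c(Cl)c4)ncnc3cc2OC)c(O)c1` is compound 3 with a different aromatic group on the hydrazone carbon: 4-(diethylamino)-2-hydroxyphenyl in place of 4-cyanophenyl on a carbon with a double bond to nitrogen

Among the compounds with values here, the only measured step that bears on this change is the one between compound 1 and compound 2, in which the same 4-cyanophenyl gave way to a hydroxyphenyl bearing a halogen, and the number moved a 40-fold lower number from compound 1 to compound 2 (1.60 log units; beyond the scatter). The group entering compound 4 is a different hydroxyphenyl, carrying a diethylamino group instead of bromine, so a drop of similar kind but uncertain size is expected. For compound 4 the estimated step is a 14-fold lower number from compound 3 to compound 4 (1.13 log units; beyond the scatter). Compound 4 is therefore expected to give about 2500 nM, with a range of 500 nM to 12000 nM.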

Compound 4, half-maximal inhibitory concentration: 29300 nM
The estimate for compound 4 lay 12-fold (1.07 log units) below the measured number, outside the stated range (above it).
By their numbers in this assay, from the lowest: compound 2; then compounds 1, 4 and 3 (each within the scatter of the next).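

In this assay, putting 4-(diethylamino)-2-hydroxyphenyl in place of 4-cyanophenyl on a carbon with a double bond to nitrogen gives a 1.2-fold lower number from compound 3 to compound 4 (0.07 log units; within the scatter), so a hydroxyphenyl group in this place does not by itself go with a lower number. The large step of a 40-fold lower number from compound 1 to compound 2 (1.60 log units; beyond the scatter) therefore cannot be read as a general effect of replacing 4-cyanophenyl with a hydroxyphenyl group. No measurement available here accounts for the contrast between these two steps.

Still open, from the compounds shown here alone, is whether the large step depends on the 3-bromo-4-hydroxyphenyl group itself or on its pairing with the oxolan-3-yl group on the oxygen, since compound 4 differs from compound 2 in more than one place. A 3-bromophenyl group or an unsubstituted 4-hydroxyphenyl group on the same carbon would help separate the contributions of the bromine and the hydroxyl.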